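A few compounds are considered here, and "the series" means these few. Any claim that something is new, unique, unknown or untested is made for them only; others in the source may bear on it.

Compound 3 `Nc1ccc(S(=O)(=O)N2CCN(c3ncc(C(O)(C(F)(F)F)C(F)(F)F)cc3-c3cccnc3)CC2)cn1` gives the lowest number of the three measured compounds in an ADME assay (liver) for metabolic stability, with Liver microsome (Rattus norvegicus) as the target, using microsomes and NADPH, with a stated time of 30 min, tested at 1 uM (a lower number here means slower removal, a higher number faster removal of the compound), at 20 mL.min-1.g-1. Compound 2 `Nc1ccc(S(=O)(=O)N2CCN(c3ncc(C(O)(C(F)(F)F)C(F)(F)F)cc3-c3ccoc3)CC2)cn1` gives 57 mL.min-1.g-1 and compound 1 `CC(C)n1cc(-c2cc(C(O)(C(F)(F)F)C(F)(F)F)cnc2N2CCN(S(=O)(=O)c3ccc(N)nc3)CC2)cn1` gives 198 mL.min-1.g-1 in this assay. Compound 4 `Cc1nc2cc(-c3cc(C(O)(C(F)(F)F)C(F)(F)F)cnc3N3CCN(S(=O)(=O)c4ccc(N)nc4)CC3)ccc2o1` carries 2-methyl-1,3-benzoxazol-5-yl in place of pyridin-3-yl on an aromatic carbon. Both measured steps that reach pyridin-3-yl bear on this change: a 9.9-fold lower number from compound 1 to compound 3 (1.00 log units; beyond the scatter) and a 2.9-fold lower number from compound 2 to compound 3 (0.45 log units; beyond the scatter), so read the other way, departing from pyridin-3-yl has so far meant a higher number. For compound 4 the step in this assay is therefore expected to be a 4.0-fold higher number from compound 3 to compound 4 (0.60 log units; beyond the scatter), a rise beyond the scatter, and compound 4 is estimated at 80 mL.min-1.g-1 within a range of 25 mL.min-1.g-1 to 250 mL.min-1.g-1.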

Compound 4, intrinsic clearance in microsomes: 99 mL.min-1.g-1
Compound 4: the middle estimate sits 1.2-fold (0.09 log units) below what was measured; the range from low to high includes it.
By their numbers in this assay, from the lowest: compound 3; then compounds 2, 4 and 1 (each within the scatter of the next, the first and the last beyond it).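

Pyridin-3-yl now gives the lowest number against three other groups on this aromatic carbon: 2-methyl-1,3-benzoxazol-5-yl in its place gives a 5.0-fold higher number from compound 3 to compound 4 (0.69 log units; beyond the scatter) in this assay. The other two steps, a 1.7-fold higher number from compound 2 to compound 4 (0.24 log units; within the scatter) and a 2.0-fold lower number from compound 1 to compound 4 (0.30 log units; within the scatter), leave compound 4 unordered against compound 2 and compound 1, so this group adds no separate level. Nothing available explains these differences. As far as these compounds go, whether an amine or a carboxylic acid on the pyridin-3-yl ring would give a number as low as that of compound 3 remains open.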